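Bulkier Substituent on the Saturated Ring of Compound 1

A few compounds are considered here, and "the series" means these few. Any claim that something is new, unique, unknown or untested is made for them only; others in the source may bear on it.

Among the compounds with values here, compound 1 `CC1(C)Cc2c(CN3CCC4(CC3)CCN(C(=O)c3ccc(N)cn3)CC4)cccc2O1` gives 8.13 nM in a functional assay for antagonist activity at C-C chemokine receptor type 8 (Homo sapiens) (on this read-out higher numbers stand for weaker inhibition and lower numbers for stronger inhibition), the lowest of the two numbers known. Compound 2 `CC1(C)Cc2c(CN3CCC4(CC3)CCN(C(=O)c3ccncc3)CC4)cccc2O1` gives 30.9 nM. Within the data shown here, the step of a 3.8-fold higher number from compound 1 to compound 2 (0.58 log units; beyond the scatter) is the only one measured, and it alters the group on the carbonyl carbon, not the saturated ring, so no measured step bears on the change to compound 3 `CC(C)(C)C1(C)Cc2c(CN3CCC4(CC3)CCN(C(=O)c3ccc(N)cn3)CC4)cccc2O1`, which differs from compound 1 by tert-butyl in place of methyl on a saturated ring carbon. Because compound 1 gives 8.13 nM, compound 3 is expected to stay close to it, with a step of a 1.8-fold higher number from compound 1 to compound 3 (0.27 log units; within the scatter), an estimate of 15 nM ranging from 4 nM to 60 nM.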

Compound 3, half-maximal inhibitory concentration in the C-C chemokine receptor type 8 assay: 2.82 nM
Compound 3: middle estimate off by 5.3-fold (0.73 log units), on the high side; measured number below the stated range.
By their numbers in the C-C chemokine receptor type 8 assay, from the lowest: compound 3; then compound 1; then compound 2.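

In the C-C chemokine receptor type 8 assay, tert-butyl in place of methyl on this saturated ring carbon, next to the ring oxygen, gives a 2.9-fold lower number from compound 1 to compound 3 (0.46 log units; beyond the scatter), so the number also moves with a change at this position, not only at the carbonyl carbon. The larger group is accepted here without loss of inhibition. The same change makes the compound more lipophilic in a physicochemical assay for lipophilicity, read by HPLC, measured as octanol-water partition, at pH 7.4; a higher number here means a more lipophilic compound, a lower number a more polar compound: the measured distribution coefficient of compound 1, 1.3, and of compound 3, 2.6, a number 1.30 log units higher (beyond the scatter) In the physicochemical assay compound 1 gives 1.3 and compound 3 gives 2.6.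

Whether the lower number in the C-C chemokine receptor type 8 assay goes with that rise in lipophilicity cannot be told from this single pair. As far as these compounds go, how an isopropyl or a hydroxymethyl group would read on this carbon remains open.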